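From Fluoro to Chloro: Estimating Compound 3

The source may hold more compounds than are shown below. What is called first, only, known or untested is meant among the compounds shown, and "the series" means these compounds.

Measured in a functional assay on BMDM cells (Mus musculus, strain C57BL/6) for inhibition, with a stated time of 2 days; a higher number here means a weaker inhibitor, a lower number a stronger inhibitor:

compound 1 `N#Cc1ccc(-c2cn(CC(=O)Nc3nccs3)nn2)cc1`: 270 nM
compound 2 `O=C(Cn1cc(-c2ccc(F)cc2)nn1)Nc1nccs1`: 190 nM

For the measured compounds named here, compound 2 holds the lower of the two numbers, but the only step between them, a 1.4-fold lower number from compound 1 to compound 2 (0.15 log units; within the scatter), lies within the scatter, so the two compounds cannot be ranked against each other. Compound 3 `O=C(Cn1cc(-c2ccc(Cl)cc2)nn1)Nc1nccs1` differs from compound 2 by chloro in place of fluoro on an aromatic carbon. Going by the values given here, no measured step shows a chloro against a fluoro; the one step that exists changes the same position in a different way and stays within the scatter. There is therefore no basis to expect a shift beyond the scatter in this assay, in either direction. Compound 3 is estimated at 170 nM, with a likely range from 70 nM to 400 nM. That estimate means a step of a 1.1-fold lower number from compound 2 to compound 3 (0.05 log units; within the scatter), expected to be within the scatter.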

Compound 3, half-maximal inhibitory concentration: 1100 nM
Beside the measured number, compound 3's estimate is 6.5-fold (0.81 log units) below it; measured number outside the range, above it.
By their numbers in this assay, from the lowest: compounds 2 and 1 (each within the scatter of the next); then compound 3.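

Swapping one halogen for another at this position is a small edit, one heavy atom for one heavy atom with no hydrogen-bond donor or acceptor involved, yet in this assay it gives a 5.8-fold higher number from compound 2 to compound 3 (0.76 log units; beyond the scatter) and so separates two close relatives. Chloro also parts from cyano, with a 4.1-fold higher number from compound 1 to compound 3 (0.61 log units; beyond the scatter) in the same assay, which makes compound 3 the weakest of the three, whereas fluoro and cyano could not be told apart. The position is therefore not indifferent to what it carries, as the earlier pair alone might have suggested. Nothing available explains this shift.

Open, going by these compounds, is whether chloro stands alone here or marks a wider trend. A bromo, a methyl, a methoxy or an amine in the same place would show which.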